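A few compounds are considered here, and "the series" means these few. Any claim that something is new, unique, unknown or untested is made for them only; others in the source may bear on it.

Measured compounds:
- compound 1 `COc1cc2nc(N3CCC[C@@H](NC4=CC(=O)c5ccccc5C4=O)C3)nc(N)c2cc1OC`: 25.1 nM
- compound 2 `COc1cc2nc(N3CCC[C@H](NC(=O)c4ccco4)C3)nc(N)c2cc1OC`: 0.282 nM
- compound 3 `COc1cc2nc(N3CCC[C@@H](NC(=O)c4ccco4)C3)nc(N)c2cc1OC`: 42.7 nM

In an assay on CHO cells for displacement of a labelled ligand from Alpha-1B adrenergic receptor (Homo sapiens), with a stated time of 30 min (a lower number here means a stronger inhibitor, a higher number a weaker inhibitor), compound 2 gives the lowest of the three numbers, and its gaps to compound 1 and compound 3 both lie beyond the scatter. The only measured step that changes one place, a 150-fold higher number from compound 2 to compound 3 (2.18 log units; beyond the scatter), concerns configuration alone, as shown by the fact that compounds 2 and 3 differ only in the configuration as drawn.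

Compound 4 `COc1cc2nc(N3CCC[C@H](N)C3)nc(N)c2cc1OC` is reached from compound 2 by hydrogen in place of (furan-2-yl)carbonyl on an amine nitrogen. Within the data shown here, no measured step matches this kind of change, so the expectation rests on the change itself. Since the group that leaves is the whole amide substituent, the expected step of a 180-fold higher number from compound 2 to compound 4 (2.25 log units; beyond the scatter) is a large rise, towards weaker binding, with wide uncertainty. For compound 4 the estimate in this assay is 50 nM, between 5 nM and 500 nM.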

Compound 4, inhibition constant: 55 nM
Beside the measured number, compound 4's estimate is 1.1-fold (0.04 log units) below it, and the stated range covers the measured number.
By their numbers in this assay, from the lowest: compound 2; then compounds 1, 3 and 4 (each within the scatter of the next, the first and the last beyond it).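

In this assay, replacing the (furan-2-yl)carbonyl with hydrogen gives a 200-fold higher number from compound 2 to compound 4 (2.29 log units; beyond the scatter), so the amino group alone does not keep the low number of compound 2. Alongside a 150-fold higher number from compound 2 to compound 3 (2.18 log units; beyond the scatter), this shows that the low number is lost both when this group leaves and when the configuration changes. Nothing given here explains why the group matters so much.

As far as these compounds go, whether a smaller acetyl or a benzoyl group on this nitrogen would restore the low number remains open. So does whether a methyl group there would have any such effect.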